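Hexyloxy in place of trifluoroethoxy: tolerability of compound 3

This account rests on a few compounds, and the source may have more. Where it says the series, first, only, none or still open, it means among the compounds named here.

Measured in an ADME assay on BCBL1 cells (Homo sapiens) for cytotoxicity, with a stated time of 7 days; a higher number here means that more compound is tolerated, a lower number that less compound is tolerated:
- Compound 1 `Nc1nc(OCC(F)(F)F)c2ncn(/C=C3/CC3(CO)CO)c2n1` gives > 20000 nM, which is a limit of the assay rather than a number.
- Compound 2 `Nc1nc(N2CCCC2)c2ncn(/C=C3/CC3(CO)CO)c2n1` gives > 20000 nM, likewise a limit and not a number.

Among the compounds with values here, compound 1 therefore stands only at a limit, and the one further value shown is a limit too, so that both sit at the same boundary (the limit of > 20000 nM in this assay, at which 2 of the 2 values shown sit). Within the data shown here, the sole measured step, a step that the two limits leave unreadable from compound 1 to compound 2, cannot be read in size or direction. Compound 3 `CCCCCCOc1nc(N)nc2c1ncn2/C=C1/CC1(CO)CO` differs from compound 1 as follows: pentyl in place of trifluoromethyl on a saturated chain carbon bound to an oxygen on an aromatic ring. Among the measured compounds shown here, no measured step bears on this change, and the two values shown give no readable step at all, so no movement beyond the scatter can be expected in this assay, only that compound 3 is likely to reach the same limit. Compound 3 is estimated at 20000 nM, between 8000 nM and 50000 nM. The expected step is a number no higher from compound 1 to compound 3 (the limit leaves the size open).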

Compound 3, half-maximal cytotoxic concentration: > 20000 nM
Compound 3 gave a limit, no number; the forecaster's own chance of this, stated with the estimate: 80%; the middle value lies on the limit itself.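

In this assay compound 3 gives > 20000 nM, a limit and not a number. Its steps to compound 1 and compound 2 cannot be read, since all three share one boundary: the limit of > 20000 nM in this assay, at which 3 of the 3 values shown sit. Left open is how far each compound's true value lies beyond that limit, and whether these changes move it at all.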